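The compounds below may be only part of what the source reports. "The series", "measured", "known", "first", "only" and "open" are said of these compounds alone.

The measured compounds, with their results in an ADME assay on MRC5 cells (Homo sapiens) for cytotoxicity, read by fluorescence and resazurin assay, with a stated time of 3 days; on this read-out higher numbers stand for weaker inhibition and lower numbers for stronger inhibition:
Compound 1 `Cc1cn(C2CCN(Cc3cccc(Oc4ccc(Cl)cc4)c3)CC2)c(=O)[nH]c1=O` gives 25100 nM.
Compound 2 `Cc1cn(C2CCN(Cc3cccc(Oc4cccc(OC(F)(F)F)c4)c3)CC2)c(=O)[nH]c1=O` gives 5260 nM.
Compound 3 `Cc1cn(C2CCN(Cc3cccc(Oc4cc(Cl)cc(Cl)c4)c3)CC2)c(=O)[nH]c1=O` gives 6730 nM.

Compound 3 stands second highest of the three numbers. Its number is within the scatter of compound 2, and its distance from compound 1 is the step of a 3.7-fold lower number from compound 1 to compound 3 (0.57 log units; beyond the scatter).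

Compound 4 `COc1ccc(Oc2cccc(CN3CCC(n4cc(C)c(=O)[nH]c4=O)CC3)c2)cc1` differs from compound 3 in one place: 4-methoxyphenyl in place of 3,5-dichlorophenyl on an oxygen on an aromatic ring. The step that bears on this is a 3.7-fold lower number from compound 1 to compound 3 (0.57 log units; beyond the scatter), where a ring with one chlorine gave the highest number of the set; the step of a 1.3-fold higher number from compound 2 to compound 3 (0.11 log units; within the scatter) shows that two other rings gave indistinguishable numbers. Among the compounds with values here, compound 4 carries a ring with a single group again, and the 4-methoxyphenyl group has no measured counterpart here. A higher number than compound 3 is therefore expected for compound 4, a step of about a 2.2-fold higher number from compound 3 to compound 4 (0.35 log units; beyond the scatter), with wide uncertainty. Compound 4 is estimated at 15000 nM, ranging from 6000 nM to 40000 nM.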

Compound 4, half-maximal inhibitory concentration: 28000 nM
Beside the measured number, compound 4's estimate is 1.9-fold (0.27 log units) below it; low and high end bracket the measured number.
By their numbers in this assay, from the lowest: compounds 2 and 3 (each within the scatter of the next); then compounds 1 and 4 (each within the scatter of the next).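

In this assay, replacing 3,5-dichlorophenyl with 4-methoxyphenyl on the oxygen raises the number (a 4.2-fold higher number from compound 3 to compound 4 (0.62 log units; beyond the scatter)), and replacing 3-(trifluoromethoxy)phenyl does the same (a 5.3-fold higher number from compound 2 to compound 4 (0.73 log units; beyond the scatter)). Methoxy and chloro on the aromatic carbon, however, cannot be told apart (a 1.1-fold higher number from compound 1 to compound 4 (0.05 log units; within the scatter)). Among these four compounds, the 4-chlorophenyl and 4-methoxyphenyl rings thus both give higher numbers than the other two rings, a split that a count of groups does not follow, since compound 2 also carries a single group.

Nothing available explains this split. From the compounds shown here alone, whether an amine or a carboxylic acid on this ring would join the higher or lower pair remains open.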